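This account rests on a few compounds, and the source may have more. Where it says the series, first, only, none or still open, it means among the compounds named here.

Compound 1 `CCOC(=O)c1ccc(-c2nn(Cc3ccccc3F)c3ccccc23)cc1`: > 10000 nM, a limit
Compound 2 `CCOC(=O)c1ccc(-c2nn(Cc3ccncc3)c3ccccc23)cc1`: > 10000 nM, a limit

In a functional assay on cells (Platelet, Homo sapiens) for inhibition (a higher number here means a weaker inhibitor, a lower number a stronger inhibitor), compound 2 stands only at a limit, > 10000 nM. Neither measured compound gives a number: the limit of > 10000 nM in this assay, at which 2 of the 2 values shown sit. Compound 3 `CCOC(=O)c1ccc(-c2nn(C(C)C)c3ccccc23)cc1` differs from compound 2 as follows: isopropyl in place of (pyridin-4-yl)methyl on an aromatic nitrogen. In compound 3, isopropyl therefore replaces (pyridin-4-yl)methyl on an aromatic nitrogen. Among the measured compounds shown here, the only measured step that bears on this is a step that the two limits leave unreadable from compound 1 to compound 2, and it has no readable size. It also keeps a ring in the group, whereas the new group has none, so the series offers no measured guide to this loss. With compound 2 at > 10000 nM, no gain in this assay is expected, and a further reading at the limit is the likeliest result. The expected change is a step that the limit leaves unreadable from compound 2 to compound 3, with no firm direction expected. Compound 3 is estimated at 15000 nM, with an expected range of 5000 nM to 50000 nM.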

Compound 3, half-maximal inhibitory concentration: > 10000 nM
Compound 3 gave a limit, no number; the forecaster's own chance of this, stated with the estimate: 75%; the middle value does not contradict the limit.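

In this assay, among the compounds shown here, no step among compound 1, compound 2 and compound 3 can be read, as all three stand at a limit: the limit of > 10000 nM in this assay, at which 3 of the 3 values shown sit.

The compounds shown leave open whether any group on the aromatic nitrogen of the shared core gives a measurable value in this assay at all.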